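The source may report more compounds than this note shows. Statements on the series, on what has been measured and on what is new or still open speak of the compounds shown alone.

Compound 1 `CCn1cc(C(CC)(CC)c2ccc(C#CC(O)(CC)CC)c(C)c2)cc1C(=O)NCC(=O)OC` opens the set; in an assay on cells for agonist activity at vitamin D3 receptor (Homo sapiens), read by microscopy (on this read-out higher numbers stand for an effect only at larger amounts of compound and lower numbers for an effect already at smaller amounts), compound 1 gives 288 nM. Compound 2 `CCn1cc(C(CC)(CC)c2ccc(C#CC(O)(CC)CC)c(C)c2)cc1C(=O)OCCO` gives 12.6 nM, and compound 3 `CCn1cc(C(CC)(CC)c2ccc(C#CC(O)(CC)CC)c(C)c2)cc1C(=O)NCC(=O)O` gives 54.3 nM, which is the second highest of the three numbers: a 5.3-fold lower number from compound 1 to compound 3 (0.72 log units; beyond the scatter), while a 4.3-fold higher number from compound 2 to compound 3 (0.63 log units; beyond the scatter). Compound 4 `CCn1cc(C(CC)(CC)c2ccc(C#CC(O)(CC)CC)c(C)c2)cc1C(=O)N[C@H](C(=O)O)C(C)C` differs from compound 3 by isopropyl in place of hydrogen on a saturated chain carbon bound to an amide-type nitrogen and a carbonyl carbon. Among the compounds with values here, no measured step touches that saturated chain carbon; a 23-fold lower number from compound 1 to compound 2 (1.36 log units; beyond the scatter) and the two steps into compound 3 all exchange the group on a carbonyl carbon and so bear only loosely on this change. With no comparable change measured, the step from compound 3 to compound 4 is expected to stay within the scatter, a 1.1-fold lower number from compound 3 to compound 4 (0.04 log units; within the scatter). Compound 4 is therefore estimated at 50 nM, in a range from 15 nM to 180 nM.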

Compound 4, half-maximal effective concentration: 12.7 nM
Compound 4: middle estimate off by 3.9-fold (0.60 log units), on the high side, and the stated range ends above it.
By their numbers in this assay, from the lowest: compounds 2 and 4 (each within the scatter of the next); then compound 3; then compound 1.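

Within the data shown here, the isopropyl group on the saturated chain carbon bound to an amide-type nitrogen and a carbonyl carbon gives the first reading at this position, and the change lies beyond the scatter (a 4.3-fold lower number from compound 3 to compound 4 (0.63 log units; beyond the scatter)). On the carbonyl carbon, (1-carboxy-2-methylpropyl)amino stands level with 2-hydroxyethoxy (a 1.0-fold higher number from compound 2 to compound 4 (0.00 log units; within the scatter)), while 1-carboxy-2-methylpropyl on the amide-type nitrogen gives a large step from (methoxycarbonyl)methyl (a 23-fold lower number from compound 1 to compound 4 (1.36 log units; beyond the scatter)). No supporting data explain these steps.

Open, from the compounds shown here alone, is how a methyl or benzyl group on the same carbon would read, and how the mirror-image form of compound 4 would compare.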